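This account rests on a few compounds, and the source may have more. Where it says the series, first, only, none or still open, it means among the compounds named here.

Compound 2 `CC1CCC(=NNc2cccnc2)c2ncc(C(=O)O)c(=O)n21` stands at the top end of what is shown. In a functional assay on the whole organism with Rattus norvegicus as the target (on this read-out higher numbers stand for an effect only at larger amounts of compound and lower numbers for an effect already at smaller amounts), compound 2 gives no number but only a limit, > 320 umol/kg. Its neighbour compound 1 `CC1CCC(=NNc2ccccc2)c2ncc(C(=O)O)c(=O)n21` gives 1.2 umol/kg in this assay. Going by the values given here, the single measured step, an at least 260-fold higher number from compound 1 to compound 2 (2.42 log units; beyond the scatter), runs against the limit of the assay (the limit of > 320 umol/kg in this assay, at which 1 of the 2 values shown sits), so its true size is not known.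

Compound 3 `CC1CCC(=NN(C)c2ccccc2)c2ncc(C(=O)O)c(=O)n21` is not yet measured. It differs from compound 2 in one place: methyl(phenyl)amino in place of (pyridin-3-yl)amino on a double-bonded nitrogen. Among the compounds with values here, this change takes out the (pyridin-3-yl)amino group whose arrival had produced the large step to compound 2, and restores a phenyl ring, now with a methyl on the amine nitrogen; for that methyl no measured step exists. Compound 3 is therefore expected to move back by a large step downward, an at least 100-fold lower number from compound 2 to compound 3 (2.02 log units; beyond the scatter), and its estimated value in this assay is 3 umol/kg, between 0.6 umol/kg and 30 umol/kg.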

Compound 3, dose for 50% inhibition: > 100 umol/kg
Compound 3: no number, only a limit (the forecaster's own chance of this, stated with the estimate: 10%); middle value at least 33-fold (1.52 log units) away from the limit.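

In this assay compound 3 gives only a limit, > 100 umol/kg. Methyl in place of hydrogen on a nitrogen on an aromatic ring produces an at least 83-fold higher number from compound 1 to compound 3 (1.92 log units; beyond the scatter), so the phenyl ring alone does not keep the effect seen with compound 1, and a change on the amine nitrogen itself costs as much as a change in the ring had seemed to. Compound 2 and compound 3 both give only limits, and the step between them cannot be read, so the two changes cannot be ranked against each other.

Going by these compounds, the true size of each loss stays unknown, and compound 1 remains the only one of the three with a number. Also open, on these data alone, is whether an ethyl on that nitrogen, or a fluorine on the phenyl ring, would keep any of the effect.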